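The source may hold more compounds than are shown below. What is called first, only, known or untested is meant among the compounds shown, and "the series" means these compounds.

Compound 1 `CCCCCCCCNC(=O)[C@@H](NC(=O)c1nccc2ccccc12)[C@@H](C)O` gives 66000 nM in a functional assay on SiHa cells (Homo sapiens) for cytotoxicity, read by MTT assay, with a stated time of 48 h; a higher number here means a weaker inhibitor, a lower number a stronger inhibitor. Compound 2 `CCCCCCCCNC(=O)[C@@H](NC(=O)/C=C/c1ccccc1)[C@@H](C)O` gives 41400 nM in this assay. For the measured compounds named here, compound 3 `C/C=C/C=C/C(=O)N[C@H](C(=O)NCCCCCCCC)[C@@H](C)O` gives 123000 nM in this assay, the highest of the three numbers, within the scatter of compound 1 and beyond it only against compound 2; the single one-site step measured, a 3.0-fold higher number from compound 2 to compound 3 (0.47 log units; beyond the scatter), concerns the acyl end of the molecule. Compound 4 `C/C=C/C=C/C(=O)N[C@H](C(=O)NCCCCCCCCCCCC)[C@@H](C)O` differs from compound 3 by butyl in place of hydrogen on a saturated chain carbon, eight bonds along the chain from an amide-type nitrogen. Going by the values given here, no measured step touches the amide-side chain, so none bears on this change, and no shift beyond the scatter is expected in this assay. Compound 4 is therefore estimated at 110000 nM, with a range of 40000 nM to 300000 nM. The expected step is a 1.1-fold lower number from compound 3 to compound 4 (0.05 log units; within the scatter).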

Compound 4, half-maximal inhibitory concentration: > 200000 nM
Compound 4 ended at the assay's limit (the forecaster's own chance of this, stated with the estimate: 15%); middle value at least 1.8-fold (0.25 log units) from the limit.
By their numbers in this assay, from the lowest: compounds 2, 1 and 3 (each within the scatter of the next, the first and the last beyond it). At a limit, above all of these: compound 4.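

Butyl in place of hydrogen on a saturated chain carbon, eight bonds along the chain from an amide-type nitrogen, gives the first reading on the amide-side chain in this assay: an at least 1.6-fold higher number from compound 3 to compound 4 (0.21 log units; that floor lies within the scatter). In this assay compound 4 stands at a limit, not at a number: the limit of > 200000 nM in this assay, at which 1 of the 4 values shown sits. The step therefore gives a direction but no size, and its floor does not separate the two compounds beyond the scatter.

On these data alone, whether a chain shorter than octyl, or one ending in an amine or a carboxylic acid, would shift the number remains open. Also open, as far as these compounds go, is how the acyl groups of compound 1 and compound 2 behave on the longer chain.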